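Chloro for Fluoro on the Aryl Arm of Compound 1

The compounds below may be only part of what the source reports. "The series", "measured", "known", "first", "only" and "open" are said of these compounds alone.

Compound 1 `CCC(=O)N1N=C(c2ccc(F)cc2)CC1c1cn(-c2ccccc2)nc1-c1ccc(Cl)c(Cl)c1` was measured in a functional assay on the whole organism (strain Wistar) for inhibition, with Rattus norvegicus as the target, read by paw edema, with stated times of 30 min and 60 min, at a dose of 50 mg/kg by the oral route (a higher number here means more inhibition at the dose given (going by the name of the read-out), a lower number less inhibition), in which compound 1 gives 63.4%. Its only measured partner, compound 2 `CC(=O)N1N=C(c2ccc(F)cc2)CC1c1cn(-c2ccccc2)nc1-c1ccc(Cl)c(Cl)c1`, gives 59.5% in this assay; the step of a number 3.9 percentage points lower from compound 1 to compound 2 (within the scatter) comes from hydrogen in place of methyl on a saturated chain carbon bound to a carbonyl carbon, and it leaves the two compounds within the scatter of each other, so neither stands apart.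

Compound 3 `CCC(=O)N1N=C(c2ccc(Cl)cc2)CC1c1cn(-c2ccccc2)nc1-c1ccc(Cl)c(Cl)c1` has not yet been measured. It differs from compound 1 by chloro in place of fluoro on an aromatic carbon, a swap that reads, one bond further out, as 4-fluorophenyl to 4-chlorophenyl. Going by the values given here, no measured step touches this part of the shared core: the one step recorded, a number 3.9 percentage points lower from compound 1 to compound 2 (within the scatter), concerns the chain at the carbonyl and was itself within the scatter. With nothing in the data pointing either way, the step of a number 0.4 percentage points lower from compound 1 to compound 3 (within the scatter) is expected to stay within the scatter. Compound 3 is therefore estimated at 63% in this assay, with a range from 50% to 76%.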

Compound 3, a percentage reported as inhibition, in the whole organism at one dose (the size of the read-out at that dose, not a potency): 61.1%
Compound 3: middle estimate off by 1.9 percentage points, on the high side; measured number inside the range.
By their numbers in this assay, from the lowest: compounds 2, 3 and 1 (each within the scatter of the next).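

Going by these compounds alone, the swap of 4-fluorophenyl to 4-chlorophenyl in this assay gives a number 2.3 percentage points lower from compound 1 to compound 3 (within the scatter) and is the first measured step on this arm of the core, so on this aromatic carbon, para to a large group, fluoro and chloro cannot be told apart at the single dose given. Set beside a number 3.9 percentage points lower from compound 1 to compound 2 (within the scatter) at the chain on the carbonyl, it means that both places probed so far on the core of compound 1 accept the swap made there, with each partner staying within the scatter of compound 1. Nothing at hand explains why the two halogens read alike at this position.

What the compounds leave open is whether this place accepts anything other than a halogen, such as a methoxy group, an amine or a carboxylic acid, and whether plain hydrogen there would read the same as fluoro or chloro. Also open, going by these compounds, is whether a longer chain on the carbonyl would move the number beyond the scatter, and whether these compounds would separate at another dose.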